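This account rests on a few compounds, and the source may have more. Where it says the series, first, only, none or still open, it means among the compounds named here.

Working notes on the series. In an ADME assay on MT4 cells (Homo sapiens) for cytotoxicity (a lower number here means that less compound is tolerated, a higher number that more compound is tolerated), compound 1 (`COC(=O)N[C@H](C(=O)NN(CCC[C@@](O)(Cc1ccccc1)C(=O)N[C@H]1c2ccccc2C[C@H]1O)Cc1ccccc1)C(C)(C)C`) gives > 10000 nM as a limit. Compound 2 (`COC(=O)N[C@H](C(=O)NN(CCC[C@@](O)(Cc1ccccc1)C(=O)N[C@H]1c2ccccc2C[C@H]1O)Cc1ccc(Br)cc1)C(C)(C)C`) gives > 10000 nM as a limit too. Compound 3 (`COC(=O)N[C@H](C(=O)NN(CCC[C@@](O)(Cc1ccccc1)C(=O)N[C@H]1c2ccccc2C[C@H]1O)Cc1ccc(-c2cncnc2)cc1)C(C)(C)C`) gives > 10000 nM as a limit as well, so it has no number of its own, and it stands with the other two values (the limit of > 10000 nM in this assay, at which 3 of the 3 values shown sit).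

Compound 4 (`COC(=O)N[C@H](C(=O)NN(CCC[C@@](O)(Cc1ccccc1)C(=O)N[C@H]1c2ccccc2C[C@H]1O)Cc1ccc(-c2nc(C(C)(C)C)cs2)cc1)C(C)(C)C`) carries 4-(tert-butyl)-1,3-thiazol-2-yl in place of pyrimidin-5-yl on an aromatic carbon of a six-membered aromatic ring of carbon only, para to a large group (4-(tert-butyl)-1,3-thiazol-2-yl in place of pyrimidin-5-yl on an aromatic carbon). The measured changes at this place offer no size: there is a step that the two limits leave unreadable from compound 1 to compound 3 and a step that the two limits leave unreadable from compound 2 to compound 3 and also a step that the two limits leave unreadable from compound 1 to compound 2 on the same carbon. No direction can be read from them, so no step beyond the scatter is expected in this assay here. The expected change is a step that the limit leaves unreadable from compound 3 to compound 4 on this reading. For compound 4 the estimated value is 15000 nM with an expected range from 5000 nM to 40000 nM as the likely span.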

Compound 4, half-maximal cytotoxic concentration: > 10000 nM
Compound 4 ended at the assay's limit; the forecaster's own chance of this, stated with the estimate: 75%; the middle value does not contradict the limit.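

In this assay compound 4 gives > 10000 nM, a limit and not a number, so its steps from compound 1, compound 2 and compound 3 cannot be read: the limit of > 10000 nM in this assay, at which 4 of the 4 values shown sit.

The compounds shown leave open at what concentration any of the four becomes cytotoxic, and whether the group on this aromatic carbon changes that concentration at all.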